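This account rests on a few compounds, and the source may have more. Where it says the series, first, only, none or still open, it means among the compounds named here.

Measured so far in a physicochemical assay for lipophilicity, read by HPLC, measured as chromatographic lipophilicity, at pH 7.4; a lower number here means a more polar compound, a higher number a more lipophilic compound:
- compound 1 `CC(C)C(=O)N1N=CCC1c1ccccc1` gives 4.4
- compound 2 `C[C@@H]1C=NN(C(=O)C(C)(C)C)[C@@H]1c1ccccc1` gives 6.5
- compound 3 `O=C(c1cn[nH]c1)N1CCC(C(=O)N2N=CCC2c2ccccc2)CC1` gives 2.1

Compound 3 is the lowest of the three numbers. Compound 1 is its nearest neighbour and compound 2 its furthest, and both gaps lie beyond the scatter.

Compound 4 `O=C(c1ccccn1)N1CCC(C(=O)N2N=CCC2c2ccccc2)CC1` is the next to be read in this assay and has no number yet. The change from compound 3 is pyridin-2-yl in place of 1H-pyrazol-4-yl on a carbonyl carbon and puts pyridin-2-yl in place of 1H-pyrazol-4-yl on a carbonyl carbon whose other neighbours are an amide-type nitrogen in a ring.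

Among the compounds with values here, no measured pair shows this swap, so the size of the step rests on the structural change alone. Within the data shown here, the anchor is compound 3 at 2.1 as the only measured compound sharing everything but the changed group. A moderate rise, beyond the scatter, is expected, with the estimated move a number 0.80 log units higher from compound 3 to compound 4 (beyond the scatter) in this assay as a working figure. For compound 4 the expected value is 2.9 as a central estimate, within an estimated range of 2.4 to 3.5 for now.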

Compound 4, distribution coefficient: 3.1
Beside the measured number, compound 4's estimate is 0.20 log units below it; the range from low to high includes it.
By their numbers in this assay, from the lowest: compound 3; then compound 4; then compound 1; then compound 2.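

In this assay, the group on this carbonyl carbon, whose other neighbours are an amide-type nitrogen in a ring, proves able to move the reading on its own: pyridin-2-yl in place of 1H-pyrazol-4-yl gives a number 1.00 log units higher from compound 3 to compound 4 (beyond the scatter). This single swap changes the ring size, the heavy-atom count and the hydrogen-bond donor count together, from 1 donor to 0, while the hydrogen-bond acceptor count stays at 1. Nothing available explains the size of this step.

Within the data shown here, with only this one pair, the contribution of each of those differences cannot be separated. Still open, as far as these compounds go, is how a phenyl, a pyridin-3-yl or a 1-methyl-1H-pyrazol-4-yl group on the same carbonyl carbon would read, and whether this step holds on another core.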